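This account rests on a few compounds, and the source may have more. Where it says the series, first, only, none or still open, it means among the compounds named here.

Compound 1 `Oc1ccc(-c2cc(-c3ccsc3)cc(-c3ccccc3O)n2)cc1` gives > 50000 nM in a functional assay on HeLa cells (Homo sapiens) for cytotoxicity, read by CCK-8 assay (on this read-out lower numbers stand for stronger inhibition and higher numbers for weaker inhibition), which is a limit of the assay.
Compound 2 `Oc1ccc(-c2cc(-c3ccsc3)cc(-c3cccc(O)c3)n2)cc1` gives 2580 nM in this assay.
Compound 3 `Oc1cccc(-c2cc(-c3ccco3)cc(-c3ccccc3O)n2)c1` gives > 50000 nM in this assay, which is a limit of the assay.

Compound 1 and compound 2 share a core and differ in one place: 3-hydroxyphenyl in place of 2-hydroxyphenyl on an aromatic carbon. That change brought an at least 19-fold lower number from compound 1 to compound 2 (1.28 log units; beyond the scatter), and the true size of this step is open-ended because compound 1 sits at the limit of > 50000 nM in this assay, at which 2 of the 3 values shown sit. How the core of compound 3 differs from the core of compound 1 is not broken down here. Compound 4 `Oc1cccc(-c2cc(-c3ccco3)cc(-c3cccc(O)c3)n2)c1` has not yet been measured in this assay; it differs from compound 3 by 3-hydroxyphenyl in place of 2-hydroxyphenyl on an aromatic carbon. Among the measured compounds shown here, this is the same kind of change as the one between compound 1 and compound 2, but not the same: in compound 1 the changed carbon is meta to a 4-hydroxyphenyl group and meta to a thiophen-3-yl group, while in compound 3 it is meta to a 3-hydroxyphenyl group and meta to a furan-2-yl group. Since compound 3 also sits at the limit of > 50000 nM in this assay, at which 2 of the 3 values shown sit, a step of a similar kind is expected, an at least 10-fold lower number from compound 3 to compound 4 (1.00 log units; beyond the scatter), resting on the earlier step of an at least 19-fold lower number from compound 1 to compound 2 (1.28 log units; beyond the scatter). Compound 4 is therefore estimated at 5000 nM, expected to fall between 1500 nM and 30000 nM.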

Compound 4, half-maximal inhibitory concentration: 5990 nM
Compound 4: the middle estimate sits 1.2-fold (0.08 log units) below what was measured; low and high end bracket the measured number.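

In this assay, 3-hydroxyphenyl in place of 2-hydroxyphenyl on the core of compound 3 brought an at least 8.3-fold lower number from compound 3 to compound 4 (0.92 log units; beyond the scatter), so the change lowers the number on this core too, in the same direction as on the core of compound 1. Both steps start from a limit of the assay rather than from a true number: the limit of > 50000 nM in this assay, at which 2 of the 4 values shown sit. As far as these compounds go, the direction therefore carries over between these two cores, but the real size of each step stays unknown and so does any difference between them: the same change on two cores in this assay, an at least 19-fold lower number (1.28 log units; beyond the scatter) from compound 1 to compound 2 and an at least 8.3-fold lower number (0.92 log units; beyond the scatter) from compound 3 to compound 4; the limit leaves it open whether they differ.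

The compounds shown test this change on only two cores, so it remains open whether it would act the same way on a core with other rings in the thiophen-3-yl or furan-2-yl place. They also leave open what would happen if the hydroxyl on this phenyl ring gave way to an amine or a carboxylic acid.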